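Swapping the Amide Substituent in a Weakly Cytotoxic Series

The compounds below may be only part of what the source reports. "The series", "measured", "known", "first", "only" and "open" are said of these compounds alone.

Measured compounds:
compound 1, `O=C(NCC1CCCCC1)c1cccc(/C=C2\CC(=O)N(c3ccccc3)C2=O)c1`, > 100000 nM
compound 2, `CCc1cccc(NC(=O)c2cccc(/C=C3\CC(=O)N(Cc4ccccc4)C3=O)c2)c1`, 80600 nM

Of the compounds shown here, two have been tested in an ADME assay on HCT-116 cells (Homo sapiens) for cytotoxicity, read by MTT assay, with a stated time of 72 h; a higher number here means a weaker inhibitor, a lower number a stronger inhibitor. Compound 1, `O=C(NCC1CCCCC1)c1cccc(/C=C2\CC(=O)N(c3ccccc3)C2=O)c1`, gives only a limit there, > 100000 nM, which is the boundary of what this assay reports rather than a measured number. Compound 2, `CCc1cccc(NC(=O)c2cccc(/C=C3\CC(=O)N(Cc4ccccc4)C3=O)c2)c1`, gives 80600 nM in this assay, a weak effect. Within the data shown here, both results therefore sit at the feeble end of the scale, and the one fact about compound 1 is the limit of > 100000 nM in this assay, at which 1 of the 2 values shown sits.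

Compound 3, `CCc1cccc(NC(=O)c2cccc(/C=C3\CC(=O)N(c4ccccc4)C3=O)c2)c1`, has not yet been measured. It differs from compound 1 in one place: 3-ethylphenyl in place of cyclohexylmethyl on an amide-type nitrogen. Among the measured compounds shown here, compound 3 shares its 3-ethylphenyl amide with compound 2 and its phenyl on the imide nitrogen with compound 1, but no step between compound 2 and compound 3 has been measured, so those two values can only be compared as they stand.

Since compound 1 sits at the limit, no direction can be read for the step; the expected change from compound 1 to compound 3 is an at least 1.1-fold lower number from compound 1 to compound 3 (0.04 log units; that floor lies within the scatter), that is, nothing beyond the usual scatter. Compound 3 is therefore estimated at 90000 nM in this assay, with a range from 30000 nM to 300000 nM.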

Compound 3, half-maximal inhibitory concentration: 81200 nM
Estimate against measurement, compound 3: 1.1-fold (0.04 log units) above; measured number inside the range.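

In this assay, placing 3-ethylphenyl in place of cyclohexylmethyl on the amide-type nitrogen gives an at least 1.2-fold lower number from compound 1 to compound 3 (0.09 log units; that floor lies within the scatter), so this position now has a measured number on one side of the step, but the smallest change consistent with the data is no larger than the normal spread between repeat measurements. The true size of the step stays unknown, and it could be small or much larger, because one end of it is a limit and not a number: the limit of > 100000 nM in this assay, at which 1 of the 3 values shown sits.

The new compound also links to compound 2, and phenyl in place of benzyl on an amide-type nitrogen in a ring gives a 1.0-fold higher number from compound 2 to compound 3 (0.00 log units; within the scatter), so with the 3-ethylphenyl amide held the same, these two compounds cannot be told apart in this read-out.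

The compounds shown leave open whether any amide substituent can bring the series clearly away from the weak end of the scale. An amine or a carboxylic acid in place of the ethyl of the 3-ethylphenyl group would test that question at this position.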